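The compounds below may be only part of what the source reports. "The series", "measured", "known", "first", "only" and "open" are said of these compounds alone.

Compound 2 `Cc1ccc(-c2cnn3c(NCc4ccccn4)cc(C)nc23)cc1` carries a 4-methylphenyl group on its shared core. In a physicochemical assay for solubility, read by HPLC, using the shake flask method, measured as kinetic solubility, with a stated time of 2 h, at pH 7.4 (a lower number here means a less soluble compound, a higher number a more soluble compound), compound 2 gives < 5000 nM, which is a limit of the assay and not a number. Compound 1 `Cc1cc(NCc2ccccn2)n2nc(C)c(-c3ccc(F)cc3)c2n1` likewise returns only a limit in this assay, < 5000 nM. Among the compounds with values here, compound 3 `Cc1cc(NCC2CCCCN2)n2nc(C)c(-c3ccccc3)c2n1` is the one compound with a number in this assay, at 189000 nM. The picture is therefore thin: the limit of < 5000 nM in this assay, at which 2 of the 3 values shown sit. The next structure, compound 4 `Cc1cc(NCc2ccccn2)n2ncc(-c3cccc(N)c3)c2n1`, is not yet measured; its difference from compound 2 is 3-aminophenyl in place of 4-methylphenyl on an aromatic carbon. Within the data shown here, no measured step covers this change, so only an expectation can be given, and a gain in solubility beyond the scatter is expected, an at least 4.0-fold higher number from compound 2 to compound 4 (0.60 log units; beyond the scatter). Compound 4 is estimated at 20000 nM, within a range from 5000 nM to 80000 nM.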

Compound 4, solubility: 160000 nM
Compound 4: middle estimate off by 8.0-fold (0.90 log units), on the low side, and the stated range ends below it.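

In this assay, 3-aminophenyl in place of 4-methylphenyl on an aromatic carbon of the five-membered ring gives an at least 32-fold higher number from compound 2 to compound 4 (1.50 log units; beyond the scatter). Within the data shown here, this is the first one-place step measured, and it shows that a change at this position alone can span a large range in this read-out. Compound 2 still holds only a limit of the assay: the limit of < 5000 nM in this assay, at which 2 of the 4 values shown sit.

The compounds shown do not separate the amine from its place on the phenyl ring. On these data alone, a 4-aminophenyl group, or a carboxylic acid on that ring, remains open at this position.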